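Notes on an unmeasured amide variation, compound 3 to compound 4

The source may report more compounds than this note shows. Statements on the series, on what has been measured and on what is new or still open speak of the compounds shown alone.

Measured compounds:
compound 1 `CN1CCN(C(=O)CNC(=O)c2ccc(S(C)(=O)=O)c([N+](=O)[O-])c2)CC1` in an assay on isolated protein for inhibition of thyroid hormone receptor beta (Homo sapiens), read by fluorescence polarization (a lower number here means a stronger inhibitor, a higher number a weaker inhibitor), gives only a limit of the assay, > 60000 nM.
compound 2 `CS(=O)(=O)c1ccc(C(=O)N2CCC(C(=O)N(Cc3ccccc3)Cc3ccccc3)CC2)cc1[N+](=O)[O-]` in this assay gives only a limit, > 60000 nM.
compound 3 `CC(C)N(C(=O)C1CCN(C(=O)c2ccc(S(C)(=O)=O)c([N+](=O)[O-])c2)CC1)C(C)C` in this assay gives only a limit, > 60000 nM.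

Compound 3 therefore stands at the limit with no actual number, and the same holds for the two other compounds: every value shown is the limit of > 60000 nM in this assay, at which 3 of the 3 values shown sit. Within the data shown here, nothing separates the three compounds within this assay, and no step between measured compounds can be counted.

Compound 4 `CN(Cc1ccccc1F)C(=O)C1CCN(C(=O)c2ccc(S(C)(=O)=O)c([N+](=O)[O-])c2)CC1` is not yet measured. It differs from compound 3 by (2-fluorobenzyl)(methyl)amino in place of diisopropylamino on a carbonyl carbon. Compound 2, which carries its own variation at the same carbonyl, likewise shows only a limit, so the amide end has not so far moved any compound off the limit.

Among the measured compounds shown here, with no measured step to rest on, the expected step that the limit leaves unreadable from compound 3 to compound 4 is one of no meaning beyond the scatter, as it starts from a limit. Compound 4 is expected to give 90000 nM, in the range 30000 nM to 300000 nM, most probably again reported only as a limit.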

Compound 4, half-maximal inhibitory concentration: > 60000 nM
Compound 4 was reported as a limit; the forecaster's own chance of this, stated with the estimate: 85%; the middle value lies beyond the limit too.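

No step can be read from compound 3 to compound 4, as both compounds give only a limit: the limit of > 60000 nM in this assay, at which 4 of the 4 values shown sit. The compounds shown leave open whether any group on the carbonyl carbon gives an actual number in this assay.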